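The source may hold more compounds than are shown below. What is called first, only, known or untested is meant among the compounds shown, and "the series" means these compounds.

Measured so far:
compound 1, `C/C(CN)=C(/F)CN(C[C@H]1Cc2ccccc2CN1)[C@H]1CCCc2cccnc21`: 44 nM
compound 2, `C/C(CN(C[C@H]1Cc2ccccc2CN1)[C@H]1CCCc2cccnc21)=C(/F)CN`: 1800 nM
compound 3, `NC(=O)NC/C=C\CN(C[C@H]1Cc2ccccc2CN1)[C@H]1CCCc2cccnc21`: 210 nM

In a functional assay on CCRF-CEM cells for antagonist activity at C-X-C chemokine receptor type 4 (Homo sapiens), read by calcium flux, with stated times of 25 min and 90 s (on this read-out lower numbers stand for stronger inhibition and higher numbers for weaker inhibition), compound 3 holds the second highest of the three numbers. Its nearest neighbour is compound 1, the step being a 4.8-fold higher number from compound 1 to compound 3 (0.68 log units; beyond the scatter); the furthest is compound 2, with an 8.6-fold lower number from compound 2 to compound 3 (0.93 log units; beyond the scatter).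

Compound 4, `N[C@H]1CC[C@H](N(C[C@H]2Cc3ccccc3CN2)[C@H]2CCCc3cccnc32)CC1`, is the next entry. It differs from compound 3 in one place: a group of 7 heavy atoms (6 carbon, 1 nitrogen; one six-membered non-aromatic ring of carbon only) in place of a group of 8 heavy atoms (5 carbon, 2 nitrogen, 1 oxygen; no ring), on an amine nitrogen. All three measured steps concern the substituent on this same amine nitrogen. The largest, a 41-fold higher number from compound 1 to compound 2 (1.61 log units; beyond the scatter), came from a rearrangement within a chain of unchanged atom count; the other two, a 4.8-fold higher number from compound 1 to compound 3 (0.68 log units; beyond the scatter) and an 8.6-fold lower number from compound 2 to compound 3 (0.93 log units; beyond the scatter), were modest. For the measured compounds named here, none of them replaces a chain by a ring, so the change to compound 4 has no direct precedent, but the record shows this position swings the read-out by modest to large amounts in either direction. Given compound 3 sits in the middle of the range and compound 1 shows a lower number can be reached here, a modest improvement is expected for compound 4, namely a 1.8-fold lower number from compound 3 to compound 4 (0.24 log units; within the scatter). Compound 4 is therefore estimated at 120 nM, with a range from 25 nM to 600 nM.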

Compound 4, half-maximal inhibitory concentration: 34 nM
For compound 4 the middle estimate is 3.5-fold (0.55 log units) above the measured one, and the stated range covers the measured number.
By their numbers in this assay, from the lowest: compounds 4 and 1 (each within the scatter of the next); then compound 3; then compound 2.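

In this assay, a chain is not required on this amine nitrogen: 4-aminocyclohexyl, the first ring substituent here, gives a clear gain over the urea-bearing chain of compound 3 (a 6.2-fold lower number from compound 3 to compound 4 (0.79 log units; beyond the scatter)) and a large gain over the 4-amino-3-fluoro-2-methylbut-2-en-1-yl chain of compound 2 (a 53-fold lower number from compound 2 to compound 4 (1.72 log units; beyond the scatter)). Against the 3-(aminomethyl)-2-fluorobut-2-en-1-yl chain of compound 1, the step (a 1.3-fold lower number from compound 1 to compound 4 (0.11 log units; within the scatter)) stays within the scatter, so a carbon-only ring and this fluorinated chain cannot be told apart on this read-out, although the two groups have different shapes on paper. Nothing among the data shown offers an explanation for these steps, and the comparison rests on the functional read-out alone.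

Open, going by these compounds, is how much of the result belongs to the ring and how much to its amine, a question that a 4-hydroxycyclohexyl group in the same place would address. Also open, on these data alone, is whether a saturated 4-aminobutyl chain would fall with compound 4 or with compound 3, and how the other ring stereoisomer of 4-aminocyclohexyl would compare.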